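Cyclobutylmethyl for cyclohexyl on the ester of compound 2

A few compounds are considered here, and "the series" means these few. Any claim that something is new, unique, unknown or untested is made for them only; others in the source may bear on it.

Compound 1, `CCNC(=O)C1=C(C)NC(=O)NC1c1ccco1`: 3%
Compound 2, `CC1=C(C(=O)OC2CCCCC2)C(c2ccco2)NC(=O)N1`: 4%

In an assay on membranes from HeLa cells for displacement of a labelled ligand from adenosine receptor A3 (Homo sapiens), read by scintillation counting, with a stated time of 180 min, tested at 1 uM (on this read-out higher numbers stand for more inhibition at the one concentration tested (going by the name of the read-out) and lower numbers for less inhibition), compound 1 gives 3% and compound 2 gives 4%. Compound 2 holds the higher of the two numbers, but the nearest point is compound 1 and the gap between the two lies within the scatter, so no order can be read from them. For the measured compounds named here, the one measured step, cyclohexyloxy in place of ethylamino on a carbonyl carbon, was a number 1 percentage points higher from compound 1 to compound 2 (within the scatter), a change within the scatter.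

Compound 3, `CC1=C(C(=O)OCC2CCC2)C(c2ccco2)NC(=O)N1`, differs from compound 2 by cyclobutylmethyl in place of cyclohexyl on an oxygen next to a carbonyl group. Going by the values given here, no measured step swaps one group on the ester oxygen for another, so the step from compound 1 to compound 2 bears on it only as a sign that the carbonyl substituent left the read-out essentially unmoved in this assay. On that basis compound 3 is expected to show a step of no change at the digits printed from compound 2 to compound 3 (within the scatter), none beyond the scatter. The estimate for compound 3 in this assay is therefore 4%, with a range from -5% to 13%.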

Compound 3, a percentage reported as inhibition, at one concentration (the size of the read-out at that concentration, not a potency): 1%
Compound 3: the middle estimate sits 3 percentage points above what was measured; the range from low to high includes it.
By their numbers in this assay, from the lowest: compounds 3, 1 and 2 (each within the scatter of the next).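

For the compounds shown here, the first step that changes only the group on the ester oxygen gave, in this assay, a number 3 percentage points lower from compound 2 to compound 3 (within the scatter) and so shows that replacing cyclohexyl with cyclobutylmethyl, a six-membered carbon ring with a four-membered one, does not separate the two esters. Set against the amide, cyclobutylmethoxy gave a number 2 percentage points lower from compound 1 to compound 3 (within the scatter) and thus became the second replacement of ethylamino on a carbonyl carbon to stay within the scatter, alongside cyclohexyloxy. No evidence is available that bears on this result.

The compounds shown cover only these two carbon rings on the ester oxygen and ethylamino on the carbonyl carbon, so they leave open whether a phenyl ring, a longer chain or a chain carrying an amine there would move the number beyond the scatter, as they do for a carboxylic acid in place of the ester. They also leave open whether a change elsewhere on the shared core would do so, and a reading at one concentration gives no potency for any of the three compounds.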